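The source may hold more compounds than are shown below. What is called first, only, known or untested is meant among the compounds shown, and "the series" means these compounds.

Compound 1 `COc1c(Nc2ccc(C#N)cc2Cl)ncnc1OC1C2COCC1CN(C(=O)OC1(C)CC1)C2` has the lowest of the two numbers measured here: in a functional assay on HEK293 cells for agonist activity at Glucose-dependent insulinotropic receptor (Homo sapiens), read by fluorescence and cAMP accumulation, with a stated time of 30 min (on this read-out lower numbers stand for an effect already at smaller amounts and higher numbers for an effect only at larger amounts of compound), compound 1 gives 7 nM, while compound 2 `CC1(OC(=O)N2CC3COCC(C2)C3Oc2cc(Nc3ccc(C#N)cc3Cl)ncn2)CC1` gives 25 nM. Among the measured compounds shown here, the only measured step, a 3.6-fold higher number from compound 1 to compound 2 (0.55 log units; beyond the scatter), concerns a different part of the molecule. Compound 3 `COc1c(Nc2ccc(C#N)cc2F)ncnc1OC1C2COCC1CN(C(=O)OC1(C)CC1)C2` differs from compound 1 by fluoro in place of chloro on an aromatic carbon. For the measured compounds named here, no measured step bears on this swap of one halogen for another, so no change beyond the scatter is expected, and the expected step is a 1.4-fold higher number from compound 1 to compound 3 (0.15 log units; within the scatter). Compound 3 is therefore estimated at 10 nM, with a range from 4 nM to 25 nM.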

Compound 3, half-maximal effective concentration: 5 nM
Estimate against measurement, compound 3: 2.0-fold (0.30 log units) above, within the range that was stated.
By their numbers in this assay, from the lowest: compounds 3 and 1 (each within the scatter of the next); then compound 2.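

Among the compounds shown here, compound 1 and compound 2 say nothing about the 2-chloro-4-cyanophenyl group, and compound 3 is the first here to change its halogen. In this assay, fluoro in place of chloro gives a 1.4-fold lower number from compound 1 to compound 3 (0.15 log units; within the scatter) and so leaves the two halogens indistinguishable at this position on this read-out. Nothing available offers an explanation for this result. Only these two halogens are shown here, so the outcome with bromo, methyl or plain hydrogen at this position remains open. Also open, on these data alone, is whether the same swap would hold in compound 2, which lacks the methoxy group.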